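The source may hold more compounds than are shown below. What is called first, only, known or untested is meant among the compounds shown, and "the series" means these compounds.

Compound 1, `Nc1n[nH]c(=O)c2c1ncn2[C@H]1C[C@H](O)[C@@H](CO)O1`, and compound 2, `Nc1n[nH]c(=O)c2ncn([C@H]3C[C@H](O)[C@@H](CO)O3)c12`, are close relatives that share the same core and the same attached groups. In an assay on isolated protein for inhibition of adenosine deaminase (Bos taurus) (a higher number here means a weaker inhibitor, a lower number a stronger inhibitor), compound 1 gives 12100 nM, while compound 2 gives 52000 nM. Of these two numbers, compound 1 has the lower one, and the gap between them lies beyond the usual scatter of the measurement, so compound 1 is the stronger inhibitor of the pair, though both are weak. Compound 3, `Nc1n[nH]c(=O)c2c1ncn2[C@@H]1O[C@H](CO)[C@@H](O)[C@H]1O`, is built from compound 1 by a single change: hydroxy in place of hydrogen on a saturated ring carbon. Going by the values given here, no measured pair in this set shows the effect of such a change, so there is no step to lean on, and the expectation rests on compound 1 alone. With compound 1 as the reference, the expected step is a 1.2-fold lower number from compound 1 to compound 3 (0.08 log units; within the scatter), small and not clearly beyond the scatter in either direction. The number expected for compound 3 in this assay is 10000 nM, with a likely range from 3000 nM to 40000 nM.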

Compound 3, inhibition constant: 10600 nM
Compound 3: middle estimate off by 1.1-fold (0.03 log units), on the low side, within the range that was stated.
By their numbers in this assay, from the lowest: compounds 3 and 1 (each within the scatter of the next); then compound 2.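

Going by these compounds alone, this is the first step in the set that shows what hydroxy in place of hydrogen does on this saturated ring carbon, which lies next to the ring atom that bears a hydroxy group and next to the ring atom that bears a large group. In this assay the change gives a 1.1-fold lower number from compound 1 to compound 3 (0.06 log units; within the scatter) and so leaves compound 1 and compound 3 indistinguishable, which means that this carbon can carry a hydroxy group with no readable effect on the number, although both compounds remain weak inhibitors. Nothing available here explains why the added hydroxy leaves the number where it is.

From the compounds shown here alone, whether a different group on this same ring carbon, such as fluorine, an amine or a methoxy group, would also leave the number in place remains open. Going by these compounds, it is equally open whether hydroxy in place of hydrogen would give a similar step on compound 2, whose number differs from that of compound 1 by more than the scatter.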